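A few compounds are considered here, and "the series" means these few. Any claim that something is new, unique, unknown or untested is made for them only; others in the source may bear on it.

In a functional assay on EC9706 cells (Homo sapiens) for cytotoxicity, read by MTT assay, with a stated time of 72 h (on this read-out lower numbers stand for stronger inhibition and higher numbers for weaker inhibition), three compounds have been measured so far:

compound 1, `O=C(CCl)Nc1ccc(C(=O)/C=C/c2ccc(Br)cc2)cc1`, gives 10100 nM
compound 2, `O=C(CCl)Nc1ccc(C(=O)/C=C/c2ccc(F)cc2)cc1`, gives 8600 nM
compound 3, `O=C(CSC(=S)N[C@H]1CCOC1=O)Nc1ccc(C(=O)/C=C/c2ccc(Br)cc2)cc1`, gives 91200 nM

All three are built on the shared core of compound 1, which carries a substituted phenyl ring at one end and a halogen-bearing phenyl ring at the other. Compound 2 differs from compound 1 in a single place: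

fluoro in place of bromo on an aromatic carbon

This change produced a 1.2-fold lower number from compound 1 to compound 2 (0.07 log units; within the scatter), so the two numbers cannot be told apart by this assay. Compound 3 differs from compound 1 at the other end of the molecule:

a group of 10 heavy atoms (5 carbon, 1 nitrogen, 2 oxygen, 2 sulfur; one five-membered non-aromatic ring with 1 hetero atom) in place of one chlorine atom, on a saturated chain carbon bound to a carbonyl carbon

Here the step is a 9.0-fold higher number from compound 1 to compound 3 (0.96 log units; beyond the scatter), and compound 3 therefore stands with the highest number of the three, both of its steps to the other compounds lying beyond the scatter.

Compound 4, `O=C(CSC(=S)N[C@H]1CCOC1=O)Nc1ccc(C(=O)/C=C/c2ccc(F)cc2)cc1`, has not yet been measured. It differs from compound 3 in the following way: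

fluoro in place of bromo on an aromatic carbon

This is the same change that separates compound 1 from compound 2, made at a place described in identical terms, and the two cores differ as set out above for compound 3 against compound 1. Since the earlier step, a 1.2-fold lower number from compound 1 to compound 2 (0.07 log units; within the scatter), stayed within the scatter, the step from compound 3 to compound 4 is expected to be small as well, estimated as a 1.2-fold lower number from compound 3 to compound 4 (0.07 log units; within the scatter). Compound 4 is therefore expected to give about 78000 nM in this assay, most likely between 40000 nM and 160000 nM.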

Compound 4, half-maximal inhibitory concentration: 46100 nM
Beside the measured number, compound 4's estimate is 1.7-fold (0.23 log units) above it; the measured number falls inside the stated range.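

In this assay, fluoro in place of bromo produces a 2.0-fold lower number from compound 3 to compound 4 (0.30 log units; within the scatter), so on this second core the change again stays within the scatter, and its size carries over from the first core with no detectable difference: the same change on two cores in this assay, a 1.2-fold lower number (0.07 log units; within the scatter) from compound 1 to compound 2 and a 2.0-fold lower number (0.30 log units; within the scatter) from compound 3 to compound 4, 1.7-fold (0.23 log units) apart, within the scatter of two such steps

The replacement of chlorine by the larger group holding the five-membered ring also carries over, since with fluoro rather than bromo on the aromatic ring it gives a 5.4-fold higher number from compound 2 to compound 4 (0.73 log units; beyond the scatter), again beyond the scatter and in the same direction as before: the same change on two cores in this assay, a 9.0-fold higher number (0.96 log units; beyond the scatter) from compound 1 to compound 3 and a 5.4-fold higher number (0.73 log units; beyond the scatter) from compound 2 to compound 4, 1.7-fold (0.23 log units) apart, within the scatter of two such steps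

Among these compounds, this agreement rests on only two cores, one halogen swap and one cell assay, and it does not show that bromo and fluoro truly differ in effect, nor does it explain why the larger group goes with higher numbers.

The compounds shown leave open whether a methoxy or nitrile group on that same aromatic carbon would leave the numbers as little changed as fluoro does. They also leave open whether an amine or a longer chain in place of the chlorine would move the numbers in the same direction as the group holding the five-membered ring.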